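The compounds below may be only part of what the source reports. "The series", "measured", "known", "first", "only" and "open" are said of these compounds alone.

Measured so far:
Compound 1, `CCOc1ccc(N/N=C2\CCC(C)n3c2ncc(C(=O)O)c3=O)cc1`, in a functional assay on the whole organism for inhibition, with Rattus norvegicus as the target (a higher number here means that more compound is needed for the effect, a lower number that less compound is needed), gives only a limit, > 100 umol/kg.
Compound 2, `CC1CC/C(=N\Nc2ccc(-c3ccccc3)cc2)c2ncc(C(=O)O)c(=O)n21`, in this assay likewise reaches only a limit, > 100 umol/kg.

Compound 2 thus stands at the edge of what this assay can report: the limit of > 100 umol/kg in this assay, at which 2 of the 2 values shown sit. Compound 3, `CNC(=O)c1ccc(N/N=C2\CCC(C)n3c2ncc(C(=O)O)c3=O)cc1`, differs from compound 2 by methylcarbamoyl in place of phenyl on an aromatic carbon. Among the compounds with values here, only one measured step exists, a step that the two limits leave unreadable from compound 1 to compound 2, and it cannot be read; no change beyond the scatter is expected in this assay from this kind of exchange. For compound 3 the estimate is 100 umol/kg, between 30 umol/kg and 400 umol/kg, which means an expected step of a number no higher from compound 2 to compound 3 (the limit leaves the size open).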

Compound 3, dose for 50% inhibition: > 100 umol/kg
Compound 3 gave a limit, no number (the forecaster's own chance of this, stated with the estimate: 70%); the middle value sits exactly at the limit.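

Compound 1, compound 2 and compound 3 all give only a limit in this assay, so no step among them can be read: the limit of > 100 umol/kg in this assay, at which 3 of the 3 values shown sit.

The compounds shown leave open what dose any of them needs for the effect, and whether ethoxy, phenyl or methylcarbamoyl makes any difference to it.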